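Dropping a Methyl in a Series Held at the Limit

The source may report more compounds than this note shows. Statements on the series, on what has been measured and on what is new or still open speak of the compounds shown alone.

Compound 1 `Cc1oc2c3c(ccc2c(=O)c1C)OC[C@H]1[C@@H]3C2=C(CCCC2=O)OC1(C)C` in a functional assay on MDA-MB-231 cells (Homo sapiens) for antiproliferative activity, read by MTT assay, with a stated time of 48 h (on this read-out lower numbers stand for stronger inhibition and higher numbers for weaker inhibition), gives > 100000 nM, a limit of the assay.
Compound 2 `Cc1oc2c3c(ccc2c(=O)c1-c1ccccc1)OC[C@H]1[C@@H]3C2=C(CCCC2=O)OC1(C)C` gives > 100000 nM, a limit of the assay.
Compound 3 `Cc1oc2c3c(ccc2c(=O)c1C)OC[C@H]1[C@@H]3C2=C(CC(C)(C)CC2=O)OC1(C)C` gives > 100000 nM, a limit of the assay.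

Compound 3 stands at a limit in this assay, and no number is known for it. The same holds for every value shown, since all of them sit at the limit (the limit of > 100000 nM in this assay, at which 3 of the 3 values shown sit). Among the compounds with values here, the one measured step, the change from methyl to phenyl, is a step that the two limits leave unreadable from compound 1 to compound 2, so its size cannot be read.

Compound 4 `Cc1coc2c3c(ccc2c1=O)OC[C@H]1[C@@H]3C2=C(CC(C)(C)CC2=O)OC1(C)C` differs from compound 3 by hydrogen in place of methyl on an aromatic carbon. Within the data shown here, no measured step concerns the removal of a methyl at this place, and the one step that exists is unreadable. Compound 4 is therefore expected to behave like compound 3 and to remain at the limit, with an expected step of a number no higher from compound 3 to compound 4 (the limit leaves the size open). For compound 4 the estimate in this assay is 100000 nM, expected to lie between 30000 nM and 300000 nM, most probably again as a limit rather than a number.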

Compound 4, half-maximal inhibitory concentration: > 100000 nM
Compound 4 was reported as a limit; the forecaster's own chance of this, stated with the estimate: 85%; the middle value lies on the limit itself.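

No step can be read between compound 3 and compound 4: both stand at a limit of the assay, and the swap of methyl for hydrogen shows no size. The compounds shown leave open how any of them ranks against the others, as every value is a limit: the limit of > 100000 nM in this assay, at which 4 of the 4 values shown sit.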